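The source may hold more compounds than are shown below. What is called first, only, known or untested is meant among the compounds shown, and "the series" means these compounds.

Measured compounds:
Compound 1 `CCNC(=O)c1noc(-c2cc(C(C)C)c(O)cc2O)c1-c1cc(CNC(C)C)no1` — 109 nM
Compound 2 `CCNC(=O)c1noc(-c2cc(C(C)C)c(O)cc2O)c1-c1cc(CNC(C)=O)no1` — 167 nM
Compound 3 `CCNC(=O)c1noc(-c2cc(C(C)C)c(O)cc2O)c1-c1cc(CNC(=O)CC)no1` — 78 nM

In a functional assay on HCT-116 cells (Homo sapiens) for inhibition (on this read-out lower numbers stand for stronger inhibition and higher numbers for weaker inhibition), compound 1 gives 109 nM, the middle one of the three numbers, and both of its neighbours lie within the scatter of it: a 1.5-fold higher number from compound 1 to compound 2 (0.19 log units; within the scatter) and a 1.4-fold lower number from compound 1 to compound 3 (0.15 log units; within the scatter). Among the compounds with values here, only the step between the two acylated analogues reaches beyond the scatter, a 2.1-fold lower number from compound 2 to compound 3 (0.33 log units; beyond the scatter), and even that is modest.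

Compound 4 `CCNC(=O)c1noc(-c2cc(C(C)C)c(O)cc2O)c1-c1cc(C(=O)NC)no1` has not been measured. It differs from compound 1 by methylcarbamoyl in place of (isopropylamino)methyl on an aromatic carbon. The steps seen so far bear on it only in part: they replace the isopropyl on the amine nitrogen by acetyl or propanoyl, or add a methyl on the chain carbon bound to the carbonyl carbon, and all remain small. None of them moves the amide onto the aromatic carbon itself, so the change to compound 4 is not directly covered. Given how little the numbers moved across compounds 1, 2 and 3, compound 4 is expected to stay close to compound 1, with a 1.2-fold higher number from compound 1 to compound 4 (0.08 log units; within the scatter) not beyond the scatter. Compound 4 is therefore estimated at 130 nM, within 50 nM to 350 nM.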

Compound 4, half-maximal inhibitory concentration: 124 nM
Compound 4: the middle estimate sits 1.0-fold (0.02 log units) above what was measured; the range from low to high includes it.
By their numbers in this assay, from the lowest: compounds 3, 1, 4 and 2 (each within the scatter of the next, the first and the last beyond it).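

Within the data shown here, all the earlier compounds carried a substituted aminomethyl group on this aromatic carbon, and compound 4 shows that a methylcarbamoyl group can stand there instead in this assay with no change beyond the scatter: a 1.1-fold higher number from compound 1 to compound 4 (0.06 log units; within the scatter). The same holds against the two acylated analogues, with a 1.6-fold higher number from compound 3 to compound 4 (0.20 log units; within the scatter) and a 1.3-fold lower number from compound 2 to compound 4 (0.13 log units; within the scatter), so compound 4 lies within the scatter of both even though those two lie beyond the scatter of each other. Nothing available here explains this result.

The compounds shown leave open whether a carboxylic acid or an unsubstituted carboxamide would be accepted on this aromatic carbon. They also leave open what a longer chain or a ring on the amide nitrogen of the methylcarbamoyl group would do.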